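The compounds below may be only part of what the source reports. "The series", "measured", "known", "first", "only" and "open" are said of these compounds alone.

In this series three esters of a shared core have been measured. Compound 1 `C=C[C@@](C)(/C=C/c1ccc(OC(C)=O)cc1)CCC=C(C)C` gives 71% in a functional assay on IMR-32 cells (Homo sapiens) for inhibition, with a stated time of 48 h, tested at 50 uM; a higher number here means more inhibition of growth at the concentration tested, a lower number less inhibition of growth. Compound 2 `C=C[C@@](C)(/C=C/c1ccc(OC(=O)CCC)cc1)CCC=C(C)C` gives 54% in this assay, and compound 3 `C=C[C@@](C)(/C=C/c1ccc(OC(=O)CCCCCCC)cc1)CCC=C(C)C` gives 51% in this assay. Compound 2 thus stands second highest of the three numbers: its gap to compound 3 is within the scatter, while its gap to compound 1 is beyond it. Both steps away from compound 1 were modest, namely a number 17 percentage points lower from compound 1 to compound 2 (beyond the scatter) and a number 20 percentage points lower from compound 1 to compound 3 (beyond the scatter). By contrast, a number 3 percentage points lower from compound 2 to compound 3 (within the scatter).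

Compound 4 `C=C[C@@](C)(/C=C/c1ccc(OC(=O)CCCCCCCCCCCCCCC)cc1)CCC=C(C)C` has not yet been measured. It differs from compound 2 by dodecyl in place of hydrogen on a saturated chain carbon, three bonds along the chain from a carbonyl carbon. The precedent that bears most directly on it, a number 3 percentage points lower from compound 2 to compound 3 (within the scatter), concerns the same place, and compound 4 only extends that change with a longer chain. No step beyond the scatter is therefore expected in this assay, with at most a slight lowering. Compound 4 is expected to give about 49% in this assay, with a range from 34% to 64%. The step thus expected is a number 5 percentage points lower from compound 2 to compound 4 (within the scatter).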

Compound 4, percent growth inhibition at one concentration: 54%
For compound 4 the middle estimate is 5 percentage points below the measured one, within the range that was stated.
By their numbers in this assay, from the lowest: compounds 3, 2 and 4 (each within the scatter of the next); then compound 1.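

In this assay, dodecyl on a saturated chain carbon, three bonds along the chain from a carbonyl carbon, gives no change at the digits printed from compound 2 to compound 4 (within the scatter), and octyl, seven bonds along the chain from a carbonyl carbon, gives a number 3 percentage points higher from compound 3 to compound 4 (within the scatter). At this place, then, the chain of compound 4 extends well past that of compound 3 without a step beyond the scatter, and the lowering seen in a number 17 percentage points lower from compound 1 to compound 2 (beyond the scatter) does not continue among these longer esters. No measurement shown here offers an explanation for this flat stretch.

The compounds shown leave open whether a chain ending in an amine or a carboxylic acid would hold the same level. They also leave open how an amide in place of the ester, or the free phenol, would compare with compound 1.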